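Adding an Ethyl Group to Compound 2

The source may hold more compounds than are shown below. What is called first, only, known or untested is meant among the compounds shown, and "the series" means these compounds.

In a functional assay for inhibition, with Sus scrofa as the target (on this read-out higher numbers stand for weaker inhibition and lower numbers for stronger inhibition), compound 1 (`CC1(C)Oc2ccc(C#N)cc2[C@@H](Oc2ccnc(O)c2)[C@]1(C)O`) gives 4 nM and compound 2 (`CC1(C)Oc2ccc(C#N)cc2[C@@H](Oc2ccc(=O)[nH]n2)[C@]1(C)O`) gives 6 nM, so the two stand level within the scatter. Compound 3 (`CCn1nc(O[C@@H]2c3cc(C#N)ccc3OC(C)(C)[C@@]2(C)O)ccc1=O`) differs from compound 2 by ethyl in place of hydrogen on an aromatic nitrogen, with ethyl in place of hydrogen on an aromatic nitrogen. Among the compounds with values here, the only measured step, a 1.5-fold higher number from compound 1 to compound 2 (0.18 log units; within the scatter), exchanges one ring for another and offers no direct precedent for substitution on that nitrogen. No change beyond the scatter is therefore expected, and the expected step is a 1.3-fold higher number from compound 2 to compound 3 (0.12 log units; within the scatter). For compound 3 the estimated value is 8 nM, with an expected range of 2 nM to 30 nM.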

Compound 3, half-maximal inhibitory concentration: 7 nM
Estimate against measurement, compound 3: 1.1-fold (0.06 log units) above; measured number inside the range.
By their numbers in this assay, from the lowest: compounds 1, 2 and 3 (each within the scatter of the next).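

Ethyl in place of hydrogen on the aromatic nitrogen gives a 1.2-fold higher number from compound 2 to compound 3 (0.07 log units; within the scatter) in this assay and so provides the first direct reading at this nitrogen, which compounds 1 and 2 could not give. In this read-out, the position carries ethyl with no change beyond the scatter, so the hydrogen of compound 2 is not required here. No measurement offered here explains this result. Going by these compounds, it remains open whether this tolerance extends beyond ethyl. A longer chain such as butyl, or a chain ending in an amine or a carboxylic acid, could still behave differently on this nitrogen.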